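The source may hold more compounds than are shown below. What is called first, only, known or untested is meant among the compounds shown, and "the series" means these compounds.

Measured compounds: compound 1 `COc1ccc(-c2cc(/C=C/C(=O)c3ccc(N)cc3)[nH]n2)cc1`, compound 2 `COc1cc(-c2cc(/C=C/C(=O)c3ccc(N)cc3)[nH]n2)cc(OC)c1OC`, compound 3 `COc1ccc(C(=O)/C=C/c2cc(-c3cc(OC)c(OC)c(OC)c3)n[nH]2)cc1OC`.

In a functional assay on SK-OV-3 cells (Homo sapiens) for cytotoxicity, read by sulforhodamine B assay, with a stated time of 48 h, tested at 0.1 uM (on this read-out lower numbers stand for a stronger effect and higher numbers for a weaker effect at the one concentration tested), compound 1 gives 103%, compound 2 gives 98% and compound 3 gives 105%. Compound 2 has the lowest of the three numbers, but compound 1 and compound 3 both lie within the scatter of it. Compound 4 `COc1ccc(-c2cc(/C=C/C(=O)c3ccc(N)cc3)[nH]n2)cc1OC` differs from compound 2 by hydrogen in place of methoxy on an aromatic carbon. Among the compounds with values here, the only measured step, a number 7 percentage points higher from compound 2 to compound 3 (within the scatter), alters the group on the carbonyl carbon rather than the ring from which the methoxy is removed, so it bears on this change only loosely. Within the data shown here, no measured step therefore points to a move beyond the scatter in this assay. For compound 4 the expected value is 100%, with a range from 86% to 114%. The expected step is a number 2 percentage points higher from compound 2 to compound 4 (within the scatter).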

Compound 4, a percentage reported as activity, at one concentration (the size of the read-out at that concentration, not a potency): 102%
Beside the measured number, compound 4's estimate is 2 percentage points below it, and the stated range covers the measured number.
By their numbers in this assay, from the lowest: compounds 2, 4, 1 and 3 (each within the scatter of the next).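

Under this assay hydrogen in place of methoxy on this aromatic carbon gives a number 4 percentage points higher from compound 2 to compound 4 (within the scatter) and methoxy in place of hydrogen on an aromatic carbon gives a number 1 percentage points lower from compound 1 to compound 4 (within the scatter) in a direct reading of this change that the earlier step did not offer. At the one concentration tested, neither removing nor adding methoxy on this ring separates the compounds. Nothing at hand bears on why these readings fall as they do.

Going by these compounds, whether an amine or a carboxylic acid in place of methoxy on this carbon would shift the number stays open. So does the behaviour of these compounds at any other concentration.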